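This account rests on a few compounds, and the source may have more. Where it says the series, first, only, none or still open, it means among the compounds named here.

Series values in a functional assay on A-375 cells (Homo sapiens) for cytotoxicity, read by MTT assay, with a stated time of 72 h; a lower number here means a stronger inhibitor, a higher number a weaker inhibitor:
- compound 1 `O=C1c2c[n+]([O-])c3ccccc3c2C(=O)c2c1c1ccccc1n2Cc1cn(C[C@H](O)CO)nn1`: 350 nM
- compound 2 `CN1CCN(CCCCn2c3c(c4ccccc42)C(=O)c2c[n+]([O-])c4ccccc4c2C3=O)CC1`: 30 nM
- compound 3 `CCCN1CCN(CCCCn2c3c(c4ccccc42)C(=O)c2c[n+]([O-])c4ccccc4c2C3=O)CC1`: 870 nM

Compound 3 has the highest number of the three in this assay, and so is the weakest inhibitor so far. Compound 4 `CN1CCN(CCCCCCn2c3c(c4ccccc42)C(=O)c2c[n+]([O-])c4ccccc4c2C3=O)CC1` differs from it as follows: 2-(4-methylpiperazin-1-yl)ethyl in place of 4-propylpiperazin-1-yl on a saturated chain carbon, four bonds along the chain from an aromatic nitrogen. In words, this is 2-(4-methylpiperazin-1-yl)ethyl in place of 4-propylpiperazin-1-yl on a saturated chain carbon, four bonds along the chain from an aromatic nitrogen.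

The most relevant measured step is the large 29-fold higher number from compound 2 to compound 3 (1.46 log units; beyond the scatter), since compound 4 shares the 4-methylpiperazin-1-yl end of compound 2. The steps of a 12-fold lower number from compound 1 to compound 2 (1.07 log units; beyond the scatter) and a 2.5-fold higher number from compound 1 to compound 3 (0.40 log units; beyond the scatter) show that this side chain can move the number in either direction. Within the data shown here, no measured compound carries 5-(4-methylpiperazin-1-yl)pentyl, so only part of the gap to compound 2 is expected to be recovered.

A lower number, moderate to large in size, is therefore expected in this assay. The expected change is a 5.8-fold lower number from compound 3 to compound 4 (0.76 log units; beyond the scatter). For compound 4 the estimated value is 150 nM, with an expected range of 30 nM to 600 nM.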

Compound 4, half-maximal inhibitory concentration: 630 nM
For compound 4 the middle estimate is 4.2-fold (0.62 log units) below the measured one; measured number outside the range, above it.
By their numbers in this assay, from the lowest: compound 2; then compounds 1, 4 and 3 (each within the scatter of the next, the first and the last beyond it).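

In this assay, rejoining the same atoms, so that 5-(4-methylpiperazin-1-yl)pentyl stands in place of 3-(4-propylpiperazin-1-yl)propyl, gives no readable difference: a 1.4-fold lower number from compound 3 to compound 4 (0.14 log units; within the scatter). The 4-methylpiperazin-1-yl end alone therefore does not carry the low number of compound 2, as the longer chain gives a 21-fold higher number from compound 2 to compound 4 (1.32 log units; beyond the scatter), so in these compounds that number is lost with either the longer chain or the 4-propyl end. Compound 4 also cannot be separated from the triazole diol: a 1.8-fold higher number from compound 1 to compound 4 (0.26 log units; within the scatter).

Nothing at hand accounts for these numbers. Open, going by these compounds, is how sharply the number depends on chain length, which a 4-(4-methylpiperazin-1-yl)butyl chain would test, and how it depends on the piperazine end, which a 4-ethylpiperazin-1-yl end on the chain of compound 2 would test.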